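The source may report more compounds than this note shows. Statements on the series, on what has been measured and on what is new or still open speak of the compounds shown alone.

Measured compounds:
Compound 1 `CCC(C)(C)Cc1c[nH]c(CCc2ccc(-c3cccc(C)n3)cc2)n1` — 106 nM
Compound 2 `CCC(C)(C)Cc1c[nH]c(CCc2ccc(-c3ccncc3)cc2)n1` — 103 nM
Compound 3 `CCC(C)(C)Cc1c[nH]c(CCc2ccc(-n3cccn3)cc2)n1` — 113 nM

In a functional assay on HEK293 cells for agonist activity at Bombesin receptor subtype-3 (Mus musculus), read by luminescence and calcium flux, with a stated time of 10 min (a higher number here means that more compound is needed for the effect, a lower number that less compound is needed), compound 2 stands among the three measured compounds with no separation from the others: the steps of a 1.0-fold lower number from compound 1 to compound 2 (0.01 log units; within the scatter) and a 1.1-fold higher number from compound 2 to compound 3 (0.04 log units; within the scatter) both fall within the scatter, as does a 1.1-fold higher number from compound 1 to compound 3 (0.03 log units; within the scatter), so none of the three can be called more or less potent than another. Compound 4 `CCC(C)(C)Cc1c[nH]c(CCc2ccc(-c3cnccn3)cc2)n1` is the unmeasured compound; it differs from compound 2 by pyrazin-2-yl in place of pyridin-4-yl on an aromatic carbon. The three measured steps all concern exchanges of this same aryl group at the same place, and none reached beyond the scatter, so a step in this assay no larger than the scatter is expected in either direction. Compound 4 is therefore estimated at 110 nM, with a range of 55 nM to 220 nM, which would be a step of a 1.1-fold higher number from compound 2 to compound 4 (0.03 log units; within the scatter).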

Compound 4, half-maximal effective concentration: 107 nM
Beside the measured number, compound 4's estimate is 1.0-fold (0.01 log units) above it, and the stated range covers the measured number.
By their numbers in this assay, from the lowest: compounds 2, 1, 4 and 3 (each within the scatter of the next).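

Pyrazin-2-yl brings to this place, para to a large group, a six-membered aromatic ring with 2 hetero atoms, which no earlier compound carried there, and in this assay the step of a 1.0-fold higher number from compound 2 to compound 4 (0.02 log units; within the scatter) stays within the scatter, as do a 1.1-fold lower number from compound 3 to compound 4 (0.02 log units; within the scatter) and a 1.0-fold higher number from compound 1 to compound 4 (0.00 log units; within the scatter). All four aryl variants therefore remain inseparable. Nothing available offers an explanation for this. Going by these compounds, whether an amine, a carboxylic acid or a longer chain at this place would move the number beyond the scatter stays open.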